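Swapping a chloro for a fluoro on the benzyl group

A few compounds are considered here, and "the series" means these few. Any claim that something is new, unique, unknown or untested is made for them only; others in the source may bear on it.

Compound 1, `CCc1ccccc1N(CC(=O)NCc1ccc(OC)c(OC)c1)S(=O)(=O)c1ccc(C)cc1`, gives 282 nM in a functional assay on CHO-K1 cells for antagonist activity at prostaglandin E2 receptor EP1 subtype (Homo sapiens), read by FLIPR and calcium flux; a higher number here means a weaker inhibitor, a lower number a stronger inhibitor.
Compound 2, `CCc1ccccc1N(CC(=O)NCc1ccccc1)S(=O)(=O)c1ccc(C)cc1`, gives 224 nM in this assay.
Compound 3, `CCc1ccccc1N(CC(=O)NCc1cccc(Cl)c1)S(=O)(=O)c1ccc(C)cc1`, gives 1410 nM in this assay.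

Compound 3 stands highest of the three numbers: a 5.0-fold higher number from compound 1 to compound 3 (0.70 log units; beyond the scatter) and a 6.3-fold higher number from compound 2 to compound 3 (0.80 log units; beyond the scatter) are both beyond the scatter, while a 1.3-fold lower number from compound 1 to compound 2 (0.10 log units; within the scatter) stays within it. Compound 4, `CCc1ccccc1N(CC(=O)NCc1ccccc1F)S(=O)(=O)c1ccc(C)cc1`, carries 2-fluorophenyl in place of 3-chlorophenyl on a saturated chain carbon bound to an amide-type nitrogen. Going by the values given here, no measured step exchanges one halogen for another, so the only guide is a 6.3-fold higher number from compound 2 to compound 3 (0.80 log units; beyond the scatter), where adding the chloro substituent raised the number. On these data alone, replacing it with a fluoro substituent is a different change whose effect is unknown; the expectation is that compound 4 moves part of the way back toward compound 2, giving a 3.5-fold lower number from compound 3 to compound 4 (0.55 log units; beyond the scatter). Compound 4 is therefore estimated at 400 nM, within 130 nM to 1200 nM.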

Compound 4, inhibition constant: 135 nM
Compound 4: the middle estimate sits 3.0-fold (0.47 log units) above what was measured; measured number inside the range.
By their numbers in this assay, from the lowest: compounds 4, 2 and 1 (each within the scatter of the next, the first and the last beyond it); then compound 3.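

Moving from 3-chlorophenyl to 2-fluorophenyl gives a 10-fold lower number from compound 3 to compound 4 (1.02 log units; beyond the scatter), so the penalty seen with the chloro compound does not apply to every halogen on this ring. Fluoro in place of hydrogen gives a 1.7-fold lower number from compound 2 to compound 4 (0.22 log units; within the scatter), and the change from 3,4-dimethoxyphenyl gives a 2.1-fold lower number from compound 1 to compound 4 (0.32 log units; beyond the scatter), so this position accepts fluoro without loss. No evidence here explains the difference between the two halogens.

Since the halogen and its ring position changed together, the compounds shown cannot separate these two effects. The 2-chlorophenyl and 3-fluorophenyl groups would settle that question.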